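Adding one methyl to the benzyl compound

A few compounds are considered here, and "the series" means these few. Any claim that something is new, unique, unknown or untested is made for them only; others in the source may bear on it.

- compound 1 `O=C(CCCCCNc1c(Nc2ccccc2)c(=O)c1=O)NO` gives 2200000 nM
- compound 2 `O=C(CCCCNc1c(Nc2ccccc2)c(=O)c1=O)NO` gives 32000000 nM
- compound 3 `O=C(CCCCCNc1c(NCc2ccccc2)c(=O)c1=O)NO` gives 5700000 nM

All three values come from a physicochemical assay for solubility, with a stated time of 24 h, tested at 30 mg/mL (on this read-out lower numbers stand for lower solubility and higher numbers for higher solubility), and compound 3 holds the middle place among them, nearest to compound 1 and furthest from compound 2. The change methyl in place of hydrogen on a saturated chain carbon bound to an aromatic carbon and a nitrogen on an aromatic ring leads from compound 3 to compound 4 `C[C@@H](Nc1c(NCCCCCC(=O)NO)c(=O)c1=O)c1ccccc1` and also reads benzyl to 1-phenylethyl. The closest measured step is a 2.6-fold higher number from compound 1 to compound 3 (0.41 log units; beyond the scatter) with benzyl in place of phenyl on a nitrogen on an aromatic ring, and it is modest. The large step of a 15-fold higher number from compound 1 to compound 2 (1.16 log units; beyond the scatter) lies in the hydroxycarbamoyl chain and bears only weakly on this group. Within the data shown here, no measured compound carries the new methyl, so neither step sizes the change directly. In this assay no step beyond the scatter is expected, with no direction favoured. The estimated step is a 1.1-fold higher number from compound 3 to compound 4 (0.06 log units; within the scatter) and it fits that expectation. For compound 4 the estimated value is 6500000 nM within an expected range of 2200000 nM to 19000000 nM on this read-out.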

Compound 4, solubility: 39000000 nM
For compound 4 the middle estimate is 6.0-fold (0.78 log units) below the measured one; measured number outside the range, above it.
By their numbers in this assay, from the lowest: compound 1; then compound 3; then compounds 2 and 4 (each within the scatter of the next).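

In this assay, one added methyl on the saturated chain carbon bound to an aromatic carbon and a nitrogen on an aromatic ring is not a silent change: the step is a 6.8-fold higher number from compound 3 to compound 4 (0.84 log units; beyond the scatter) and it goes in the same direction as the earlier benzyl for phenyl change. Taken from the phenyl group, the 1-phenylethyl group gives an 18-fold higher number from compound 1 to compound 4 (1.25 log units; beyond the scatter) and so shows that a large step can also arise at this nitrogen, where the earlier large step lay in the hydroxycarbamoyl chain. Nothing at hand accounts for the rise.

On these data alone, whether an ethyl group or the mirror-image 1-phenylethyl group moves the read-out in the same direction stays open. Also open, as far as these compounds go, is whether the methyl gives a comparable step on the hydroxycarbamoyl chain of compound 2.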